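The source may report more compounds than this note shows. Statements on the series, on what has been measured and on what is new or still open speak of the compounds shown alone.

Compound 1 `CO[C@@H]1[C@@H](OC)[C@H](c2ccccc2)O[C@@H]2CO[C@@H](c3ccccc3)O[C@@H]12`, compound 2 `CO[C@@H]1[C@@H](OC)[C@H](c2ccccc2)O[C@@H]2CO[C@@H](Cc3ccccc3)O[C@@H]12` and compound 3 `CO[C@@H]1[C@@H](OC)[C@H](c2ccccc2)O[C@@H]2CO[C@@H](c3ccc(Cl)cc3)O[C@@H]12` share one core; they differ only in the group held on a saturated ring carbon that sits between two ring oxygen atoms. In a functional assay on HEL cells (Homo sapiens) for cytotoxicity (a higher number here means that more compound is tolerated, a lower number that less compound is tolerated), compound 1 gives "not determined" (no result reported). In this assay compound 2 likewise gives "not determined" (no result reported). For compound 3 the result in this assay is a limit of the assay rather than a number, > 50 ug/mL. So compound 3 stands at the limit of > 50 ug/mL in this assay, at which 1 of the 3 values shown sits, the one bounded entry among the three, and there is no measured step to compare with.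

Compound 4 `CO[C@@H]1[C@@H](OC)[C@H](c2ccccc2)O[C@@H]2CO[C@@H](c3ccc4ccccc4c3)O[C@@H]12` has not yet been measured. It differs from compound 3 by naphthalen-2-yl in place of 4-chlorophenyl on a saturated ring carbon. For the measured compounds named here, no step between measured compounds shows how such an exchange moves this read-out. A change of this kind is not expected to shift this assay beyond the usual scatter, so the step of a number no higher from compound 3 to compound 4 (the limit leaves the size open) is estimated as close to none. Compound 4 is therefore expected to give about 50 ug/mL, within a range from 20 ug/mL to 100 ug/mL, quite possibly again only as a limit.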

Compound 4, half-maximal cytotoxic concentration: > 50 ug/mL
Compound 4 was reported as a limit; the forecaster's own chance of this, stated with the estimate: 65%; the middle value sits exactly at the limit.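

In this assay, for the compounds shown here, compound 3 and compound 4 are both reported only as a limit, so no step between them can be read. The compounds shown leave open how far either lies past that limit, and whether naphthalen-2-yl in place of 4-chlorophenyl changes this read-out at all.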